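A few compounds are considered here, and "the series" means these few. Any claim that something is new, unique, unknown or untested is made for them only; others in the source may bear on it.

Three compounds have so far been measured in an ADME assay on NHDF cells (Homo sapiens) for cytotoxicity, read by MTT assay, with a stated time of 72 h; on this read-out lower numbers stand for stronger inhibition and higher numbers for weaker inhibition:

compound 1, `COc1cccc(/C=C2\CCC/C(=C\c3ccc(Br)cc3)C2=O)c1OC`, gives 21400 nM;
compound 2, `COc1ccccc1/C=C1\CCC/C(=C\c2cccc(OC)c2OC)C1=O`, gives 31300 nM;
compound 3, `COc1ccc(/C=C2\CCC/C(=C\c3ccc(Br)cc3)C2=O)cc1OC`, gives 13100 nM.

Compound 1 and compound 2 share one core and differ in a single place: 2-methoxyphenyl in place of 4-bromophenyl on a double-bonded chain carbon bound to a double-bonded ring carbon. This exchange produced a 1.5-fold higher number from compound 1 to compound 2 (0.17 log units; within the scatter), so the two compounds cannot be told apart on this read-out.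

Compound 3 is built from the same atoms as compound 1, joined differently; the difference between the two cores is not broken down here. Compound 3 has the lowest of the three numbers. Going by the values given here, compound 1 lies within the scatter of it, while compound 2 lies beyond the scatter, so compound 3 and compound 2 are the only pair that can be ordered with confidence.

Compound 4, `COc1ccccc1/C=C1\CCC/C(=C\c2ccc(OC)c(OC)c2)C1=O`, has not yet been measured in this assay. It stands to compound 3 exactly as compound 2 stands to compound 1: 2-methoxyphenyl in place of 4-bromophenyl on a double-bonded chain carbon bound to a double-bonded ring carbon. The place of the exchange is described in the same words in both pairs, so this is the same change, made for a second time on a different core.

Among the compounds with values here, the expected step is a 1.5-fold higher number from compound 3 to compound 4 (0.16 log units; within the scatter), because the only earlier instance of this change gave a 1.5-fold higher number from compound 1 to compound 2 (0.17 log units; within the scatter), a shift that stayed within the scatter. On that basis the estimated value for compound 4 is 19000 nM, with the likely range running from 9000 nM to 40000 nM.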

Compound 4, half-maximal inhibitory concentration: 18100 nM
The estimate for compound 4 lay 1.0-fold (0.02 log units) above the measured number; the range from low to high includes it.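

In this assay, putting 2-methoxyphenyl in place of 4-bromophenyl on a double-bonded chain carbon bound to a double-bonded ring carbon gave a 1.4-fold higher number from compound 3 to compound 4 (0.14 log units; within the scatter), so these two compounds cannot be told apart on this read-out. Set beside the earlier instance, the change reads the same on both cores: the same change on two cores in this assay, a 1.5-fold higher number (0.17 log units; within the scatter) from compound 1 to compound 2 and a 1.4-fold higher number (0.14 log units; within the scatter) from compound 3 to compound 4, 1.1-fold (0.02 log units) apart, within the scatter of two such steps This shows that in these two pairs the exchange stayed inside the ordinary noise of the measurement whichever core carried it, but it does not show that the change has a real effect of a fixed size, since both steps are too small to separate from scatter, and two pairs cannot establish a rule for the whole series.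

The compounds shown vary only in aryl groups bearing methoxy groups or bromine, so it remains open whether an amine, a carboxylic acid or a longer alkoxy chain on those aromatic rings would move the number beyond the scatter. On these data alone, it also remains open whether the agreement between the two pairs would hold on a third core, or in any read-out other than this assay.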